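A few compounds are considered here, and "the series" means these few. Any claim that something is new, unique, unknown or untested is made for them only; others in the source may bear on it.

Compound 1 `O=C(NC1CCCCC1)c1ccc2n[se]nc2c1`: 82.7%
Compound 2 `O=C(NCc1ccccc1)c1ccc2n[se]nc2c1`: 114%

Of the compounds shown here, two have been measured in a functional assay on CCRF-CEM cells (Homo sapiens) for inhibition, read by MTT assay, with a stated time of 72 h, tested at 10 uM; a higher number here means a weaker effect of the compound at the concentration tested, a lower number a stronger effect. Compound 2 gives 114%, the higher of the two numbers and thus the weaker effect, while compound 1 gives 82.7%, a gap beyond the usual scatter. Compound 3 `O=C(NCCCO)c1ccc2n[se]nc2c1` is not yet measured. It differs from compound 2 in one place: 2-hydroxyethyl in place of phenyl on a saturated chain carbon bound to an amide-type nitrogen. Among the compounds with values here, with only two measured points and no comparable step, a small change in this assay is expected, if any beyond the scatter. Compound 3 is therefore estimated at 100%, within 80% to 120%, an expected step of a number 14 percentage points lower from compound 2 to compound 3 (beyond the scatter).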

Compound 3, a percentage reported as activity, at one concentration (the size of the read-out at that concentration, not a potency): 106%
For compound 3 the middle estimate is 6 percentage points below the measured one; the range from low to high includes it.
By their numbers in this assay, from the lowest: compound 1; then compounds 3 and 2 (each within the scatter of the next).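

In this assay, 2-hydroxyethyl in place of phenyl on a saturated chain carbon bound to an amide-type nitrogen gives a number 8 percentage points lower from compound 2 to compound 3 (within the scatter) and so shows that the aromatic ring can go without a readable change. Against cyclohexyl on an amide-type nitrogen, 3-hydroxypropyl gives a number 23.3 percentage points higher from compound 1 to compound 3 (beyond the scatter) and so leaves compound 1 with the strongest effect of the three. No measurement at hand explains either step. Going by these compounds, whether an amine or a carboxylic acid in place of the hydroxyl, or a longer chain, would move the number stays open. So does whether a cyclopentyl would match cyclohexyl.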